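This account rests on a few compounds, and the source may have more. Where it says the series, first, only, none or still open, it means among the compounds named here.

The measured compounds in this study:

Compound 1, `C/C(=C\c1cc(C2=CCCCC2)co1)C(N)=O`, in a functional assay on HeLa cells (Homo sapiens) for cytotoxicity, read by CCK-8 assay, with a stated time of 24 h (on this read-out lower numbers stand for stronger inhibition and higher numbers for weaker inhibition), gives > 50000 nM, which is a limit of the assay and not a number.
Compound 2, `C/C(=C\c1cc(-c2ccc(C)cc2)cs1)C(N)=O`, in this assay gives > 50000 nM, again a limit rather than a number.
Compound 3, `C/C(=C\c1cccc(-c2ccccc2)c1)C(N)=O`, in this assay gives 15700 nM.

Compound 2 therefore stands at the limit of this assay; only compound 3 yields a measured number, and even that is a weak one. Among the measured compounds shown here, of what is known, (the limit of > 50000 nM in this assay, at which 2 of the 3 values shown sit), so the set offers no measured step from which a trend could be read.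

Compound 4, `C/C(=C\c1cc(-c2ccc([N+](=O)[O-])cc2)cs1)C(N)=O`, is the next compound to be measured. It differs from compound 2 by nitro in place of methyl on an aromatic carbon, in words: nitro in place of methyl on an aromatic carbon. For the measured compounds named here, nothing among the measured compounds tells how such a change acts in this assay, so the step from compound 2 to compound 4 is expected to be an at least 1.1-fold lower number from compound 2 to compound 4 (0.04 log units; that floor lies within the scatter), that is, no change beyond the scatter or at most a modest one. On that basis compound 4 is expected to give about 45000 nM in this assay, within a range from 12000 nM to 100000 nM, and it may well be reported only as a limit once more.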

Compound 4, half-maximal inhibitory concentration: 2900 nM
Compound 4: the middle estimate sits 16-fold (1.19 log units) above what was measured; measured number outside the range, below it.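

Nitro in place of methyl on an aromatic carbon gives an at least 17-fold lower number from compound 2 to compound 4 (1.23 log units; beyond the scatter) in this assay, so this position, on a six-membered aromatic ring of carbon only and para to a large group, is one where a single change of substituent carries a compound from the limit of the assay to a measured number. Among the compounds shown here, the earlier compounds offered no such comparison, and this pair is the first to show that the read-out responds to a change in one place on the shared core. The size of the step is only a floor, not an exact figure, because the value of compound 2 is a limit and not a number: the limit of > 50000 nM in this assay, at which 2 of the 4 values shown sit.

The compounds shown leave open whether this drop belongs to nitro itself or would also appear with another group at the same position, such as an amine, a nitrile or a carboxylic acid. They also leave open whether the same exchange would act in the same way on the core of compound 1 or of compound 3, since one pair in one assay sets no pattern.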